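The source may hold more compounds than are shown below. What is called first, only, known or untested is meant among the compounds shown, and "the series" means these compounds.

In a functional assay on thoracic aorta (Rattus norvegicus, strain Wistar), with a stated time of 15 min (on this read-out higher numbers stand for an effect only at larger amounts of compound and lower numbers for an effect already at smaller amounts), compound 1 `COc1ccc(Br)cc1C(C)NC(=O)NS(=O)(=O)c1ccccc1` gives > 300000 nM, which is a limit of the assay and not a number. Compound 2 `CCOc1ccc(Br)cc1C(C)NC(=O)NS(=O)(=O)c1ccccc1` gives > 300000 nM, which is also a limit. Compound 2 thus stands at the limit of > 300000 nM in this assay, at which 2 of the 3 values shown sit. Compound 3 `CCOc1ccc(Br)cc1C(C)NC(=O)NS(=O)(=O)c1ccc(Cl)cc1` gives a true number, 171000 nM. Chloro in place of hydrogen on an aromatic carbon makes an at least 1.7-fold lower number from compound 2 to compound 3 (0.24 log units; that floor lies within the scatter).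

Compound 4 `CC(C)Oc1ccc(Br)cc1C(C)NC(=O)NS(=O)(=O)c1ccccc1` has not yet been measured. Its difference is methyl in place of hydrogen on a saturated chain carbon bound to an oxygen on an aromatic ring and a saturated chain carbon. The closest measured change, methyl in place of hydrogen on a saturated chain carbon bound to an oxygen on an aromatic ring, is a step that the two limits leave unreadable from compound 1 to compound 2. The chloro step lies at a different place on the molecule and says little here. Neither step therefore supports a change beyond the scatter in this assay. The expected result is a number no higher from compound 2 to compound 4 (the limit leaves the size open), with no clear shift in either direction. For compound 4 the estimate is 300000 nM, with an expected range from 150000 nM to 600000 nM.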

Compound 4, half-maximal effective concentration: 143000 nM
Beside the measured number, compound 4's estimate is 2.1-fold (0.32 log units) above it; measured number below the stated range.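

In this assay, going by these compounds alone, ethoxy to isopropoxy gives an at least 2.0-fold lower number from compound 2 to compound 4 (0.32 log units; beyond the scatter), the first step at this carbon bound to the oxygen that can be read at all. Isopropyl in place of methyl on the same oxygen gives an at least 2.0-fold lower number from compound 1 to compound 4 (0.32 log units; beyond the scatter), so the group on this oxygen can move the read-out beyond the scatter, which the unreadable methyl-to-ethyl step could not show. Both steps are floors and not full sizes, and the true gaps may be larger: the limit of > 300000 nM in this assay, at which 2 of the 4 values shown sit.

As far as these compounds go, what a longer chain such as butyl, or an amine at the end of a chain, would do on this oxygen stays open. From the compounds shown here alone, it is also open whether the chloro on the other aromatic ring, seen in compound 3, would add to the isopropoxy change in a single compound.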